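This account rests on a few compounds, and the source may have more. Where it says the series, first, only, none or still open, it means among the compounds named here.

Measured in a functional assay on U2OS cells for antagonist activity at C-X-C chemokine receptor type 3 (Homo sapiens), read by beta-arrestin recruitment; on this read-out lower numbers stand for stronger inhibition and higher numbers for weaker inhibition: compound 1 `COc1ncc(-c2nc(C(F)(F)F)sc2N2CCN(C(=O)Cn3cnc4cccnc43)[C@H](C)C2)cn1` gives 177 nM; compound 2 `CCOc1ncc(-c2nc(C(F)(F)F)sc2N2CCN(C(=O)Cn3cnc4cccnc43)[C@H](C)C2)cn1` gives 20 nM; compound 3 `COc1ncc(-c2nc(C(F)(F)F)sc2N2CCN(C(=O)Cn3nc(C)nc3C)[C@H](C)C2)cn1` gives 558 nM.

Compound 3 stands highest of the three numbers. Its nearest neighbour is compound 1, the gap being a 3.2-fold higher number from compound 1 to compound 3 (0.50 log units; beyond the scatter). Compound 2 lies furthest from it, with the two values far apart.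

Compound 4 `Cc1nc(C)n(CC(=O)N2CCN(c3sc(C(F)(F)F)nc3-c3cnc(C4CC4)nc3)C[C@H]2C)n1` differs from compound 3 by cyclopropyl in place of methoxy on an aromatic carbon. Among the measured compounds shown here, the only measured step at this position is an 8.9-fold lower number from compound 1 to compound 2 (0.95 log units; beyond the scatter), where enlarging the group on the aromatic oxygen lowered the number well beyond the scatter. Here the oxygen leaves and a ring of carbon only enters, so that step is a guide to size but not a direct match; a modest lowering is expected rather than a large one, with the direction not certain. Compound 4 is therefore estimated at 250 nM, range 70 nM to 900 nM, a step of a 2.2-fold lower number from compound 3 to compound 4 (0.35 log units; beyond the scatter).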

Compound 4, half-maximal inhibitory concentration: 349 nM
The estimate for compound 4 lay 1.4-fold (0.14 log units) below the measured number, within the range that was stated.
By their numbers in this assay, from the lowest: compound 2; then compounds 1, 4 and 3 (each within the scatter of the next, the first and the last beyond it).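

In this assay, replacing methoxy with cyclopropyl gives a 1.6-fold lower number from compound 3 to compound 4 (0.20 log units; within the scatter), so removing the oxygen and its hydrogen-bond acceptor at this aromatic carbon does not shift the number beyond the scatter. This contrasts with the earlier change on that oxygen, an 8.9-fold lower number from compound 1 to compound 2 (0.95 log units; beyond the scatter), although that step was read with a different amide side chain. No supporting evidence accounts for either step. Still open, from the compounds shown here alone, is whether cyclopropyl behaves the same with the side chain of compound 1. A propoxy group or a dimethylamino group at this carbon also remains untested in the compounds shown.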